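Fluoro on the phenyl ring of compound 1

The source may report more compounds than this note shows. Statements on the series, on what has been measured and on what is new or still open speak of the compounds shown alone.

Going by the values given here, compound 1 `C[C@H](Nc1nc2cc(Cl)c(F)cc2s1)c1ccccc1` gives 36600 nM in a functional assay on Ehrlich cells (Mus musculus) for cytotoxicity, read by MTT assay, with a stated time of 24 h; on this read-out higher numbers stand for weaker inhibition and lower numbers for stronger inhibition; it is one of two numbers so far, and compound 2 `CC[C@H](Nc1nc2cc(Cl)c(F)cc2s1)c1ccccc1` gives 32200 nM, within the scatter of compound 1. The step of a 1.1-fold lower number from compound 1 to compound 2 (0.06 log units; within the scatter) alters the saturated chain and says nothing about the aromatic ring. Compound 3 `C[C@H](Nc1nc2cc(Cl)c(F)cc2s1)c1ccc(F)cc1` carries fluoro in place of hydrogen on an aromatic carbon, phenyl to 4-fluorophenyl. Among the compounds with values here, no measured step bears on this change, so no step beyond the scatter is expected in this assay. Compound 3 is estimated at 36000 nM, range 15000 nM to 85000 nM. The step expected for compound 3 is a 1.0-fold lower number from compound 1 to compound 3 (0.01 log units; within the scatter).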

Compound 3, half-maximal inhibitory concentration: 35400 nM
Estimate against measurement, compound 3: 1.0-fold (0.01 log units) above; the measured number falls inside the stated range.
By their numbers in this assay, from the lowest: compounds 2, 3 and 1 (each within the scatter of the next).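

The phenyl ring now has its first measured change: in this assay, fluoro in place of hydrogen on an aromatic carbon, para to a large group, gives a 1.0-fold lower number from compound 1 to compound 3 (0.01 log units; within the scatter) and does not move the number beyond the scatter. Together with the earlier step on the saturated chain, neither of the two places changed so far has shifted the number beyond the scatter. No measured evidence bears on the reason for this result.

Still open, on these data alone, is whether a larger group at this ring position, such as methoxy, an amine or a carboxylic acid, would behave as fluoro does. Also open, as far as these compounds go, is how fluoro behaves on the other carbons of the phenyl ring.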